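A few compounds are considered here, and "the series" means these few. Any claim that something is new, unique, unknown or untested is made for them only; others in the source may bear on it.

Compound 1 `O=C(O)CNC(=O)c1c(O)c2ccc(Cl)cc2n(Cc2ccc(C(F)(F)F)cc2)c1=O`: 16 10^-6 cm/s
Compound 2 `O=C(O)CNC(=O)c1c(O)c2c(n(Cc3nc4ccccc4s3)c1=O)CCOC2`: < 2.1 10^-6 cm/s
Compound 3 `O=C(O)CNC(=O)c1c(O)c2c(n(Cc3ccc(C(F)(F)F)cc3)c1=O)COC2`: 4.2 10^-6 cm/s

These numbers come from an ADME assay on LLC-PK1 cells (Sus scrofa) for permeability, with a stated time of 3 h, tested at 1 uM; a lower number here means that the compound crosses the layer more slowly, a higher number that the compound crosses the layer faster. The entry for compound 2 is a limit of the assay and not a number. Compound 3, at 4.2 10^-6 cm/s, has the lower of the two true numbers, and compound 1, at 16 10^-6 cm/s, lies higher by more than the usual scatter.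

Compound 4 `O=C(O)CNC(=O)c1c(O)c2c(n(Cc3ccc(OC(F)(F)F)cc3)c1=O)COC2` carries trifluoromethoxy in place of trifluoromethyl on an aromatic carbon. Going by the values given here, no measured pair shows this change, so compound 3, at 4.2 10^-6 cm/s, serves as the starting point. The expected change, a 1.2-fold higher number from compound 3 to compound 4 (0.08 log units; within the scatter), stays within the scatter. For compound 4 the estimated value is 5 10^-6 cm/s, within an expected range of 2.5 10^-6 cm/s to 10 10^-6 cm/s.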

Compound 4, apparent permeability: 5.2 10^-6 cm/s
Compound 4: middle estimate off by 1.0-fold (0.02 log units), on the low side; low and high end bracket the measured number.
By their numbers in this assay, from the lowest: compounds 3 and 4 (each within the scatter of the next); then compound 1. At a limit, below all of these: compound 2.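

Going by these compounds alone, the earlier compounds held no pair differing in one place, so this is the first reading of a change at this group, on an aromatic carbon para to a large group. In this assay, trifluoromethoxy in place of trifluoromethyl gives a 1.2-fold higher number from compound 3 to compound 4 (0.09 log units; within the scatter), so the two groups cannot be told apart here. Nothing among the measurements shown explains this step.

Going by these compounds, whether an amine or a nitrile at this position would shift the number beyond the scatter stays open. So does whether the same swap would behave alike on the core of compound 1.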